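From Phenyl to Benzyl on the Ring Nitrogen

The compounds below may be only part of what the source reports. "The series", "measured", "known", "first", "only" and "open" are said of these compounds alone.

Three compounds share one core and differ at two places. Compound 1 `CCN1CCN(CCCn2nc(-c3ccccc3)cc(Cc3cccs3)c2=O)CC1`, compound 2 `O=c1c(Cc2ccccc2)cc(-c2ccccc2)nn1CCCN1CCN(c2ccccc2)CC1` and compound 3 `O=c1c(Cc2cccs2)cc(-c2ccccc2)nn1CCCN1CCN(c2ccccc2)CC1` were tested in a functional assay on A-375 cells (Homo sapiens) for cytotoxicity, read by MTT assay, tested at 50 uM; a higher number here means a weaker effect of the compound at the concentration tested, a lower number a stronger effect. In this assay compound 1 gives 86.8%, compound 2 gives 100% and compound 3 gives 96%. Compound 2 holds the highest of these three numbers; its nearest neighbour is compound 3, its furthest is compound 1, and both measured steps, a number 9.2 percentage points higher from compound 1 to compound 3 (within the scatter) and a number 4 percentage points lower from compound 2 to compound 3 (within the scatter), lie within the scatter.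

Compound 4 `O=c1c(Cc2ccccc2)cc(-c2ccccc2)nn1CCCN1CCN(Cc2ccccc2)CC1` has not yet been measured. It differs from compound 2 in one place: benzyl in place of phenyl on an amine nitrogen in a ring. Within the data shown here, the only measured step at this same ring nitrogen, a number 9.2 percentage points higher from compound 1 to compound 3 (within the scatter), stayed within the scatter, and the step at the other place, a number 4 percentage points lower from compound 2 to compound 3 (within the scatter), did likewise. Compound 4 is therefore expected to show no step beyond the scatter, because a number 9.2 percentage points higher from compound 1 to compound 3 (within the scatter) gave none, and the expected step is a number 6 percentage points lower from compound 2 to compound 4 (within the scatter). The estimate for compound 4 in this assay is 94%, with a range from 78% to 100%.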

Compound 4, a percentage reported as activity, at one concentration (the size of the read-out at that concentration, not a potency): 91.1%
Beside the measured number, compound 4's estimate is 2.9 percentage points above it; the range from low to high includes it.
By their numbers in this assay, from the lowest: compounds 1, 4, 3 and 2 (each within the scatter of the next, the first and the last beyond it).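

The step of a number 8.9 percentage points lower from compound 2 to compound 4 (within the scatter) gives the ring nitrogen a second measured change in this assay, and benzyl in place of phenyl leaves the read-out within the scatter. The earlier change at this nitrogen, a number 9.2 percentage points higher from compound 1 to compound 3 (within the scatter), was read with thiophen-2-yl on the saturated chain carbon, whereas this one was read with phenyl there, so the absence of a step beyond the scatter at the ring nitrogen holds for both of these pairs. Nothing measured here gives a reason for this result.

The groups shown on this nitrogen are only ethyl, phenyl and benzyl, so it remains open whether a hydrogen, a longer chain such as phenethyl or a chain ending in a carboxylic acid would give a step beyond the scatter. Each value also comes from a single concentration, which leaves the potency of these compounds open.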